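This account rests on a few compounds, and the source may have more. Where it says the series, first, only, none or still open, it means among the compounds named here.

Measured so far:
Compound 1, `COc1cc(/C=C/C(=O)c2cccc(-n3cc(-c4ccccc4)[nH]c3=O)c2)cc(OC)c1OC`, gives 1510 nM.
Compound 2, `COc1cc(/C=C/C(=O)c2cccc(-n3cc(-c4ccccc4)[nH]c3=O)c2)ccc1O`, gives 2180 nM.
Compound 3, `O=C(/C=C/c1cccc(O)c1)c1cccc(-n2cc(-c3ccc(Cl)cc3)[nH]c2=O)c1`, gives 550 nM.

All three numbers come from a functional assay on UO-31 cells (Homo sapiens) for inhibition; on this read-out lower numbers stand for stronger inhibition of growth and higher numbers for weaker inhibition of growth. Compound 2 has the highest number of the three. Its nearest neighbour is compound 1, whose number is lower, but the gap lies within the scatter of repeated measurements, so the two cannot be told apart. Compound 3 lies furthest away, with a lower number beyond the scatter; as compound 3 differs from compound 2 in more than one place, that gap cannot be tied to any single change.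

The unmeasured compound 4, `COc1ccc(-c2cn(-c3cccc(C(=O)/C=C/c4ccc(O)c(OC)c4)c3)c(=O)[nH]2)cc1`, differs from compound 2 in a single place: methoxy in place of hydrogen on an aromatic carbon. Cut one bond further out, the same difference reads phenyl to 4-methoxyphenyl. Going by the values given here, no pair of measured compounds shows this change on its own, so there is no measured step to lean on. The account therefore expects only a small step in this assay from compound 2 to compound 4, of about the size of the scatter, with the direction uncertain. The expected step is a 1.4-fold lower number from compound 2 to compound 4 (0.13 log units; within the scatter). Compound 4 is estimated to give 1600 nM, within a range from 500 nM to 5000 nM.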

Compound 4, concentration for 50% growth inhibition: 5190 nM
Compound 4: the middle estimate sits 3.2-fold (0.51 log units) below what was measured; the measured number lies above the stated range.
By their numbers in this assay, from the lowest: compound 3; then compounds 1 and 2 (each within the scatter of the next); then compound 4.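

In this assay, going by these compounds alone, the change from phenyl to 4-methoxyphenyl gives a 2.4-fold higher number from compound 2 to compound 4 (0.38 log units; beyond the scatter), the first measured step that isolates a single change. It shows that this position, para to a large group, is not silent: adding methoxy there goes with weaker inhibition of growth, by a modest step, although compound 4 still gives a measurable 5190 nM. No measurement shown here bears on why this step occurs.

From the compounds shown here alone, this is a single pair, so it remains open whether the step belongs to methoxy itself or would appear with other groups at this position, such as an amine, a carboxylic acid or a longer chain like ethoxy. Going by these compounds, it is equally open whether the same change would give a step of similar size and direction on a different partner, such as compound 1 with its other substitution on the far ring, since the step has been read only against the background of compound 2.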